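Benzamido end group on the aminopropyl series

The compounds below may be only part of what the source reports. "The series", "measured", "known", "first", "only" and "open" are said of these compounds alone.

Values in a functional assay on MDA-MB-435 cells (Homo sapiens) for cytotoxicity, read by MTT assay, with a stated time of 72 h; a higher number here means a weaker inhibitor, a lower number a stronger inhibitor:
- compound 1 `NCCCNc1c(C(=O)NCc2ccc(F)cc2)nc(Br)c2cccnc12`: 5000 nM
- compound 2 `O=C(NCc1ccc(F)cc1)c1nc(Br)c2cccnc2c1NCc1ccc(F)cc1`: > 20000 nM (a limit of the assay)
- compound 3 `CN(C)CCCNc1c(C(=O)NCc2ccc(F)cc2)nc(Br)c2cccnc12`: 7000 nM
- compound 4 `O=C(NCCCNc1c(C(=O)NCc2ccc(F)cc2)nc(Br)c2cccnc12)c1ccccc1`: not yet measured

Within the data shown here, of the two actual numbers, compound 3 stands within the scatter of its only numeric neighbour: a 1.4-fold higher number from compound 1 to compound 3 (0.15 log units; within the scatter). The next change is benzamido in place of dimethylamino on a saturated chain carbon, three bonds along the chain from a nitrogen on an aromatic ring, with benzamido in place of dimethylamino on a saturated chain carbon, three bonds along the chain from a nitrogen on an aromatic ring. Among the measured compounds shown here, the closest precedent, an aromatic ring replacing the amine-bearing chain end, is an at least 4.0-fold higher number from compound 1 to compound 2 (0.60 log units; beyond the scatter). Its reverse counterpart is an at least 2.8-fold lower number from compound 2 to compound 3 (0.45 log units; beyond the scatter). A modest move to a higher number is therefore expected in this assay. The expected step is a 2.1-fold higher number from compound 3 to compound 4 (0.33 log units; beyond the scatter). For compound 4 the estimated value is 15000 nM, with an expected range of 6000 nM to 40000 nM.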

Compound 4, half-maximal inhibitory concentration: > 20000 nM
Compound 4 ended at the assay's limit; the forecaster's own chance of this, stated with the estimate: 40%; middle value at least 1.3-fold (0.12 log units) from the limit.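

In this assay compound 4 gives > 20000 nM, which is a limit of the assay. At this chain position, benzamido in place of dimethylamino gives an at least 2.8-fold higher number from compound 3 to compound 4 (0.45 log units; beyond the scatter), and benzoyl on the amine nitrogen gives an at least 4.0-fold higher number from compound 1 to compound 4 (0.60 log units; beyond the scatter), so a change at the chain end alone, with the 4-fluorophenyl group absent, moves the number beyond the scatter. The step between compound 2 and compound 4 cannot be read, since both values are limits: the limit of > 20000 nM in this assay, at which 2 of the 4 values shown sit.

Open, from the compounds shown here alone, is whether the benzene ring or the amide carbonyl carries this shift. An acetamido or a benzylamino end on the same chain would separate the two.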